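Changing the Amide Cap on an Oral Bioavailability Lead

A few compounds are considered here, and "the series" means these few. Any claim that something is new, unique, unknown or untested is made for them only; others in the source may bear on it.

Measured compounds:
- Compound 1, `CCn1c(-c2cnc(C)nc2)nc2c(O[C@H]3CCN(C(=O)C4CC4)C3)ncnc21`: 64%
- Compound 2, `CCn1c(-c2cnc(C)nc2)nc2c(N[C@H]3CCN(C(=O)C4CCC4)C3)ncnc21`: 74%
- Compound 3, `CCn1c(-c2ccc(C(F)(F)F)nc2)nc2c(O[C@H]3CCN(C(=O)c4cocn4)C3)ncnc21`: 100%

Three compounds of the shared core have been examined in an ADME assay on the whole organism (Rattus norvegicus, strain Wistar Han) for pharmacokinetics; a higher number here means that a larger share of the oral dose reaches the circulation, a lower number that a smaller share of the oral dose reaches the circulation. Compound 3 gives the highest value of the three. Its nearest neighbour is compound 2, whose value lies lower by a margin beyond the scatter, and the furthest is compound 1, lower still and also beyond the scatter. Within the data shown here, compounds 1 and 2 differ from compound 3 in more than one place, so no single step between them can be read off; their values simply show the lower end of what this series has produced so far.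

Compound 4, `CCn1c(-c2ccc(C(F)(F)F)nc2)nc2c(O[C@H]3CCN(C(=O)[C@H]4C[C@@H](OC)C4)C3)ncnc21`, has not yet been measured in this assay. It differs from compound 3 in one place: 3-methoxycyclobutyl in place of 1,3-oxazol-4-yl on a carbonyl carbon. Compound 3 already stands at the top of the possible scale, so the step from compound 3 to compound 4 cannot go upward; a move within the scatter, or a modest drop, is what one would expect. The step of a number 18 percentage points lower from compound 3 to compound 4 (beyond the scatter) is therefore estimated as a small decrease. Compound 4 is expected to give 82% in this assay, in a range from 55% to 100%.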

Compound 4, oral bioavailability: 39%
Beside the measured number, compound 4's estimate is 43 percentage points above it; the whole stated range lies above it.
By their numbers in this assay, from the lowest: compound 4; then compounds 1 and 2 (each within the scatter of the next); then compound 3.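

In this assay, the group on the carbonyl carbon of the ring amide proves to be far from a neutral place in the molecule: with the rest of compound 3 held fixed, 3-methoxycyclobutyl in place of 1,3-oxazol-4-yl gives a number 61 percentage points lower from compound 3 to compound 4 (beyond the scatter). This is the only step shown that can be read at a single place, and so the first direct sign that oral exposure in this series depends strongly on this group. The change replaces a five-membered aromatic ring bearing two hetero atoms with a four-membered carbon ring that carries a methoxy group and two defined stereocentres, and nothing measured here bears on the reason for the drop.

As far as these compounds go, it remains open whether the drop belongs to the methoxy group, the four-membered ring, the stereochemistry or the departure of the aromatic ring; a plain cyclobutyl, the other stereoisomer of 3-methoxycyclobutyl or a 1,3-thiazol-4-yl group at this place would help separate these. Also open, from the compounds shown here alone, is how a cap bearing a dimethylamino group would behave here, and whether the step keeps its size when the other parts of the molecule differ.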